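Swapping a Phenyl for a Propyl Beside the Hydroxyl

A few compounds are considered here, and "the series" means these few. Any claim that something is new, unique, unknown or untested is made for them only; others in the source may bear on it.

Compound 1 `C#CCOC(=O)C1=C(N)Oc2ccc(-c3cc(OC)cc(OC)c3)cc2C1CC(O)c1ccccc1` carries a terminal alkyne ester, an amino group and a dimethoxyphenyl group on its core, with a hydroxy(phenyl)methyl side chain. Within the data shown here, in a functional assay on HL60/MX2 cells (Homo sapiens) for inhibition, with a stated time of 48 h (a higher number here means a weaker inhibitor, a lower number a stronger inhibitor), compound 1 gives 54000 nM, the higher of the two numbers measured so far and therefore the weaker inhibitor of the pair. Compound 2 `C#CCOC(=O)CC1C(C(=O)OCC#C)=C(N)Oc2ccc(-c3cccc(N)c3)cc21` differs in several places at once, and in this assay compound 2 gives 540 nM, a gap that lies well beyond the usual scatter.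

Among the measured compounds shown here, compound 3 `C#CCOC(=O)C1=C(N)Oc2ccc(-c3cc(OC)cc(OC)c3)cc2C1CC(O)CCC` is the one new compound; its change from compound 1 is propyl in place of phenyl on a saturated chain carbon bound to an oxygen on a saturated carbon and a saturated chain carbon. For the measured compounds named here, no measured pair shows this kind of change, so no direction can be read from the data. The step of a 1.1-fold higher number from compound 1 to compound 3 (0.05 log units; within the scatter) is expected to be small, plausibly within the scatter. Compound 3 is accordingly estimated to give 60000 nM, with a range from 15000 nM to 200000 nM.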

Compound 3, half-maximal inhibitory concentration: 35800 nM
Estimate against measurement, compound 3: 1.7-fold (0.22 log units) above; the measured number falls inside the stated range.
By their numbers in this assay, from the lowest: compound 2; then compounds 3 and 1 (each within the scatter of the next).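

In this assay, propyl in place of phenyl on a saturated chain carbon bound to an oxygen on a saturated carbon and a saturated chain carbon gives a 1.5-fold lower number from compound 1 to compound 3 (0.18 log units; within the scatter). This first reading at this position puts the two compounds within the scatter of each other, so the numbers do not separate a group with six carbons and an aromatic ring from an open chain with three carbons. No measurement is available that accounts for this result.

Going by these compounds, whether an amine, a carboxylic acid or a longer chain at this place would also stay within the scatter remains open. Compound 2 differs from both compounds in several places, so the data cannot show which of its changes sets its number.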